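This account rests on a few compounds, and the source may have more. Where it says the series, first, only, none or still open, it means among the compounds named here.

Three compounds have been measured in an assay on HEK293 cells for inhibition of Steryl-sulfatase (Homo sapiens), tested at 0.1 uM; on this read-out higher numbers stand for a stronger effect at the one concentration tested and lower numbers for a weaker effect:

Compound 1 `CCN(Cc1ccccn1)c1ccc(C(=O)N2CCc3ccc(OS(N)(=O)=O)cc3C2)cc1`: 42.5%
Compound 2 `CCCN(CCC)c1ccc(C(=O)N2CCc3ccc(OS(N)(=O)=O)cc3C2)cc1`: 36.6%
Compound 3 `CCN(Cc1ccccn1)c1cccc(C(=O)N2CCc3ccc(OS(N)(=O)=O)cc3C2)c1`: 6.5%

Compound 1 and compound 2 share a core and differ in one place, (dipropylamino in place of ethyl((pyridin-2-yl)methyl)amino on an aromatic carbon). This change gave a number 5.9 percentage points lower from compound 1 to compound 2 (within the scatter). Compound 3 has the same atoms as compound 1 joined differently; the difference between the two cores is not broken down here. In this assay compound 3 is the lowest of the three, lying beyond the scatter under both compound 1 and compound 2.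

Compound 4 `CCCN(CCC)c1cccc(C(=O)N2CCc3ccc(OS(N)(=O)=O)cc3C2)c1` has not yet been measured. It is made from compound 3 by dipropylamino in place of ethyl((pyridin-2-yl)methyl)amino on an aromatic carbon. Going by the values given here, this is the same kind of change as the one from compound 1 to compound 2, not the same one: there the entering group sat para to a large group, here it sits meta to a large group. Since the earlier change was within the scatter, a step of similar size, a number 3.5 percentage points lower from compound 3 to compound 4 (within the scatter), is expected here because compound 3 starts at 6.5%. Compound 4 is therefore estimated at 3%, expected between -10% and 18%.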

Compound 4, a percentage reported as inhibition, at one concentration (the size of the read-out at that concentration, not a potency): 8.3%
For compound 4 the middle estimate is 5.3 percentage points below the measured one, within the range that was stated.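

In this assay, putting dipropylamino in place of ethyl((pyridin-2-yl)methyl)amino on the core of compound 3 gave a number 1.8 percentage points higher from compound 3 to compound 4 (within the scatter), and this step agrees with the one seen on the core of compound 1: the same change on two cores in this assay, a number 5.9 percentage points lower (within the scatter) from compound 1 to compound 2 and a number 1.8 percentage points higher (within the scatter) from compound 3 to compound 4, 7.7 percentage points apart, within the scatter of two such steps. On these two cores, then, the same swap stays within the scatter, even though the group sits para to a large group in one case and meta to a large group in the other. Going by these compounds alone, this does not show that the two groups are interchangeable in general: the comparison covers only two cores and one pair of groups, and each percentage gives the size of the effect at a single concentration, so a difference in effect at other concentrations could go unseen.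

Going by these compounds, it remains open whether other amines in the same place, such as diethylamino, dibutylamino or a morpholine ring, would also stay within the scatter on both cores. A carboxylic acid in that place is a further open case.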